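Chain-end acids: clearance notes ahead of compound 4

A few compounds are considered here, and "the series" means these few. Any claim that something is new, unique, unknown or untested is made for them only; others in the source may bear on it.

Values in an ADME assay on the whole organism (strain CD-1) for pharmacokinetics, with Mus musculus as the target, at a dose of 3 mg/kg by the intravenous route; on this read-out higher numbers stand for fast clearance and lower numbers for slow clearance
- compound 1 `CC(CCCCOc1ccccc1CN(C)C(=O)c1ccc(-c2ccco2)cc1)C(=O)O` gives 3 mL/min/kg
- compound 2 `CN(Cc1ccccc1OCCCCC(C)(C)C(=O)O)C(=O)c1ccc(-c2ccco2)cc1` gives 1.3 mL/min/kg
- compound 3 `CN(Cc1ccccc1OCCC[C@@H]1C[C@H]1C(=O)O)C(=O)c1ccc(-c2ccco2)cc1` gives 0.6 mL/min/kg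

Compound 2, at 1.3 mL/min/kg in this assay, stands second highest of the three, reached by a 2.3-fold lower number from compound 1 to compound 2 (0.36 log units; beyond the scatter) and left by a 2.2-fold lower number from compound 2 to compound 3 (0.34 log units; beyond the scatter) on the way down. Compound 4 `C/C(=C\CCCOc1ccccc1CN(C)C(=O)c1ccc(-c2ccco2)cc1)C(=O)O` carries 2-carboxyprop-1-en-1-yl in place of 2-carboxy-2-methylpropyl on a saturated chain carbon, three bonds along the chain from an oxygen on an aromatic ring. Within the data shown here, no measured step makes this exact change. The closest guides are the two modest steps above, since compound 1 also lacks the second methyl and sits higher, at 3 mL/min/kg on the same scale. The expected step, a 1.5-fold higher number from compound 2 to compound 4 (0.19 log units; within the scatter), is upward and smaller than those measured steps. Compound 4 is estimated at 2 mL/min/kg, with an expected range from 0.8 mL/min/kg to 5 mL/min/kg in this read-out.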

Compound 4, clearance: 4 mL/min/kg
Estimate against measurement, compound 4: 2.0-fold (0.30 log units) below, and the stated range covers the measured number.
By their numbers in this assay, from the lowest: compound 3; then compound 2; then compounds 1 and 4 (each within the scatter of the next).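

In this assay, 2-carboxyprop-1-en-1-yl at this chain end gives a 3.1-fold higher number from compound 2 to compound 4 (0.49 log units; beyond the scatter) and a 6.7-fold higher number from compound 3 to compound 4 (0.82 log units; beyond the scatter), whereas replacing 2-carboxypropyl with it gives a 1.3-fold higher number from compound 1 to compound 4 (0.12 log units; within the scatter). Adding the double bond to the chain end of compound 1 therefore makes no difference beyond the scatter, and the low numbers stay with the 2-carboxy-2-methylpropyl of compound 2 and the 2-carboxycyclopropyl of compound 3. Nothing at hand explains these differences. As far as these compounds go, whether a cyclobutane ring at the same place, or a tetrazole in place of the carboxylic acid, would keep the low numbers remains open.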